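The source may report more compounds than this note shows. Statements on the series, on what has been measured and on what is new or still open speak of the compounds shown alone.

For the measured compounds named here, compound 1 `COc1cc2ncnc(NNC(=S)NC(=O)c3ccc(C(F)(F)F)cc3)c2cc1OC` is the weaker of the two compounds measured so far: in a functional assay on KB cells (Homo sapiens) for cytotoxicity, read by MTT assay, with a stated time of 72 h (on this read-out lower numbers stand for stronger inhibition and higher numbers for weaker inhibition), compound 1 gives 8840 nM, the highest number of the two. Its nearest neighbour on this read-out is compound 2 `O=C(NC(=S)NNc1ncnc2ccccc12)c1ccc(Cl)cc1`, which in this assay gives 3940 nM; the gap between these two values lies beyond the usual scatter, but the two structures differ in more than one place, so the two values say nothing about any single change.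

Compound 3 `COc1cc2ncnc(NNC(=S)NC(=O)c3ccccc3F)c2cc1OC` keeps the core of compound 1 and differs from it in one place: 2-fluorophenyl in place of 4-(trifluoromethyl)phenyl on a carbonyl carbon. Going by the values given here, no measured pair shows this change on its own, and there is nothing in the numbers to suggest a large move either way; the expected step in this assay from compound 1 to compound 3 is a 1.2-fold lower number from compound 1 to compound 3 (0.07 log units; within the scatter), that is, none beyond the scatter. Compound 3 is therefore estimated to give 7500 nM in this assay, with a range of 2500 nM to 22000 nM, before the measurement is known.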

Compound 3, half-maximal inhibitory concentration: 4070 nM
Compound 3: middle estimate off by 1.8-fold (0.27 log units), on the high side; measured number inside the range.
By their numbers in this assay, from the lowest: compounds 2 and 3 (each within the scatter of the next); then compound 1.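

With the core of compound 1 held fixed, 2-fluorophenyl in place of 4-(trifluoromethyl)phenyl on a carbonyl carbon gives, in this assay, a 2.2-fold lower number from compound 1 to compound 3 (0.34 log units; beyond the scatter), a modest step. This shows that the group on this carbonyl carbon can by itself move the number beyond the scatter, which compound 1 and compound 2 could not show, since they differ in more than one place. No measurement shown here bears on why the number moves.

This single step changes both the substituent and where it sits on the phenyl ring, and the compounds shown do not separate these two changes. From the compounds shown here alone, it also remains open how a plain phenyl or an aminophenyl would read at this position, and whether the step would hold on the core of compound 2.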